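Removing a Hydroxyethyl Side Chain from a Potent Antagonist

This account rests on a few compounds, and the source may have more. Where it says the series, first, only, none or still open, it means among the compounds named here.

Compound 2 `O=C(Nc1ccc2c(c1)NC(=O)C(CCO)O2)C1CCN(c2cc(F)c(F)c(F)c2)CC1` stands lowest of the two measured compounds: in a functional assay for antagonist activity at transient receptor potential cation channel subfamily V member 1 (Homo sapiens), read by FLIPR and calcium flux (on this read-out higher numbers stand for weaker inhibition and lower numbers for stronger inhibition), compound 2 gives 5 nM, whereas compound 1 `O=C(Nc1cccc2[nH]ccc12)C1CCN(c2cccc(C(F)(F)F)c2)CC1` gives 230 nM, a gap well beyond the usual scatter. Compound 3 `O=C1COc2ccc(NC(=O)C3CCN(c4cc(F)c(F)c(F)c4)CC3)cc2N1` keeps the core of compound 2 and changes one group: hydrogen in place of 2-hydroxyethyl on a saturated ring carbon. Among the measured compounds shown here, no measured pair shows this change, so in this assay a small loss is expected, possibly within the scatter. Compound 3 is expected to give about 10 nM, within 3 nM to 40 nM. The expected step is a 2.0-fold higher number from compound 2 to compound 3 (0.30 log units; within the scatter).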

Compound 3, half-maximal inhibitory concentration: 59 nM
Beside the measured number, compound 3's estimate is 5.9-fold (0.77 log units) below it; measured number outside the range, above it.
By their numbers in this assay, from the lowest: compound 2; then compound 3; then compound 1.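

In this assay, replacing the 2-hydroxyethyl group on the saturated ring carbon next to the ring oxygen with hydrogen gives a 12-fold higher number from compound 2 to compound 3 (1.07 log units; beyond the scatter). This is the first change in a single place among these compounds, and it shows that the side chain contributes substantially to the strong inhibition seen with compound 2. No measurement here gives a reason for the loss.

On these data alone, it remains open whether the hydroxyl or the carbon chain matters, which a plain ethyl group could help separate. A longer chain ending in an amine or a carboxylic acid might also tell how much this position tolerates.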